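Cyclobutyl to dimethylamino on the sulfonyl sulfur

This account rests on a few compounds, and the source may have more. Where it says the series, first, only, none or still open, it means among the compounds named here.

Measured compounds:
compound 1, `O=C([C@@H]1CCCN(S(=O)(=O)c2ccc(S(=O)(=O)C3CCC3)cc2)C1)N1CCC(F)(F)CC1`, 12.6 nM
compound 2, `CCN(CC)S(=O)(=O)c1ccc(S(=O)(=O)N2CCC[C@@H](C(=O)N3CCC(OC)CC3)C2)cc1`, 50 nM
compound 3, `CCN(CC)S(=O)(=O)c1ccc(S(=O)(=O)N2CCC[C@@H](C(=O)N3CCC(C(F)(F)F)CC3)C2)cc1`, 110 nM

All three were tested in a functional assay on MIA PaCa-2 cells (Homo sapiens) for inhibition, read by MTT assay, with a stated time of 3 days; a higher number here means a weaker inhibitor, a lower number a stronger inhibitor. Compound 1 gives the lowest number of the three; the gap to compound 2 is beyond the scatter, and the gap to compound 3 is wider still. Among the measured compounds shown here, the only single-point step among the measured compounds is a 2.2-fold higher number from compound 2 to compound 3 (0.34 log units; beyond the scatter), which concerns the saturated ring and not the sulfonyl.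

Compound 4, `CN(C)S(=O)(=O)c1ccc(S(=O)(=O)N2CCC[C@@H](C(=O)N3CCC(F)(F)CC3)C2)cc1`, differs from compound 1 by dimethylamino in place of cyclobutyl on a sulfonyl sulfur. For the measured compounds named here, no measured step isolates this change. Going by the values given here, compounds 2 and 3 carry diethylamino on the sulfonyl sulfur where compound 1 carries cyclobutyl, but they also differ from compound 1 on the saturated ring carbon, so their values cannot be read as the sulfonyl change alone; they show only that compounds with an amino group on that sulfur can stay in this assay within a moderate distance of compound 1.

The expectation is therefore a small step, most likely toward a somewhat higher number, of about a 2.0-fold higher number from compound 1 to compound 4 (0.30 log units; within the scatter). Compound 4 is estimated at 25 nM, with a range from 8 nM to 80 nM.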

Compound 4, half-maximal inhibitory concentration: 72.4 nM
For compound 4 the middle estimate is 2.9-fold (0.46 log units) below the measured one; low and high end bracket the measured number.
By their numbers in this assay, from the lowest: compound 1; then compounds 2, 4 and 3 (each within the scatter of the next, the first and the last beyond it).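

In this assay, the change on the sulfonyl sulfur now has a measured size of its own, free of any difference elsewhere in the molecule: a 5.7-fold higher number from compound 1 to compound 4 (0.76 log units; beyond the scatter). The earlier compounds shown here could not show this, as those carrying an amino group on that sulfur also differed from compound 1 on the saturated ring carbon; this pair shows that, with the rest of compound 1 held constant, the position is sensitive to replacing cyclobutyl with dimethylamino. No measurement at hand says what lies behind this step.

A single pair cannot separate the loss of the four-membered carbon ring from the arrival of nitrogen on the sulfur: isopropyl on the sulfonyl sulfur would have no ring and no nitrogen, while azetidin-1-yl would keep a four-membered ring and place nitrogen there. It also remains open whether the same step would appear with methoxy or trifluoromethyl on the saturated ring carbon, as the compounds shown pair those groups only with diethylamino and offer no cyclobutyl partner for either.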